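Replacing a Diamine Side Chain with a Primary Amide

The source may hold more compounds than are shown below. What is called first, only, known or untested is meant among the compounds shown, and "the series" means these compounds.

Measured compounds:
compound 1 `NCCCc1c[nH]c2c(F)cccc12`: 26 nM
compound 2 `NCC(N)CCc1c[nH]c2ccc(F)cc12`: 26 nM
compound 3 `NCCCc1c[nH]c2ccc(C(=O)O)cc12`: "not active" (no number reported)

In an assay on isolated protein for inhibition of Myeloperoxidase (Homo sapiens), read by ELISA, with a stated time of 5 min (on this read-out lower numbers stand for stronger inhibition and higher numbers for weaker inhibition), compound 2 gives 26 nM, level with compound 1 at the digits shown and within the usual scatter of it. Compound 3 returned no number in this assay. Compound 4 `NC(=O)CCCc1c[nH]c2ccc(F)cc12` is not yet measured. It differs from compound 2 in one place: carbamoylmethyl in place of 1,2-diaminoethyl on a saturated chain carbon, two bonds along the chain from an aromatic carbon. Among the measured compounds shown here, no measured pair shows a step of this kind, and compound 3 differs in a different place, so it gives no guide. Compound 4 is nonetheless expected to be weaker than compound 2 in this assay, beyond the scatter. The step expected is a 19-fold higher number from compound 2 to compound 4 (1.28 log units; beyond the scatter). Compound 4 is estimated at 500 nM, with a range from 100 nM to 5000 nM.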

Compound 4, half-maximal inhibitory concentration: 18 nM
The estimate for compound 4 lay 28-fold (1.44 log units) above the measured number, and the stated range ends above it.
By their numbers in this assay, from the lowest: compounds 4, 1 and 2 (each within the scatter of the next).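

In this assay, carbamoylmethyl in place of 1,2-diaminoethyl at this saturated chain carbon gives a 1.4-fold lower number from compound 2 to compound 4 (0.16 log units; within the scatter) and so stays within the scatter. This pair shows that, on this core, the 1,2-diaminoethyl group is not required for a number at this level, and that a primary amide can stand in its place. Nothing measured here bears on why the two groups read alike. Still open, going by these compounds, is whether a secondary amide, a carboxylic acid or a longer chain ending in the primary amide would read the same at this position. Also open, on these data alone, is whether a single primary amine there would do so.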